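Furan-3-yl to thiophen-3-yl on the shared core

The compounds below may be only part of what the source reports. "The series", "measured", "known", "first", "only" and "open" are said of these compounds alone.

Of the compounds shown here, two have numbers so far. In a functional assay on K562 cells (Homo sapiens), read by MTT assay, with a stated time of 72 h (on this read-out lower numbers stand for stronger inhibition and higher numbers for weaker inhibition), compound 1 (`C#Cc1cn([C@@H]2O[C@H](CO)[C@@H](O)[C@H]2O)c2ncnc(OC)c12`) gives 300 nM. In this assay compound 2 (`CSc1ncnc2c1c(-c1ccoc1)cn2[C@@H]1O[C@H](CO)[C@@H](O)[C@H]1O`) gives 60 nM, the lower of the two numbers, with a gap to compound 1 that lies beyond the scatter. These two compounds differ in more than one place, so their gap assigns nothing to a single group.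

Compound 3 (`CSc1ncnc2c1c(-c1ccsc1)cn2[C@@H]1O[C@H](CO)[C@@H](O)[C@H]1O`) is the next to be read: thiophen-3-yl in place of furan-3-yl on an aromatic carbon. Among the measured compounds shown here, no measured pair yet shows this exchange. The expectation therefore rests on compound 2 at 60 nM and on the matching counts of the two groups. The expected step is no change at the digits printed from compound 2 to compound 3 (within the scatter), none beyond the scatter, with no direction favoured. For compound 3 the estimate is 60 nM, with an expected range of 20 nM to 200 nM.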

Compound 3, half-maximal inhibitory concentration: 450 nM
Compound 3: middle estimate off by 7.5-fold (0.88 log units), on the low side, outside the stated range (above it).
By their numbers in this assay, from the lowest: compound 2; then compounds 1 and 3 (each within the scatter of the next).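

In this assay this position does not treat furan-3-yl and thiophen-3-yl alike: the exchange gives a 7.5-fold higher number from compound 2 to compound 3 (0.88 log units; beyond the scatter) on the shared core. The two groups match in heavy-atom count, ring size, hydrogen-bond donors, hydrogen-bond acceptors and charge, and differ only in oxygen against sulfur as the ring hetero atom, so matching counts do not make these two groups interchangeable at this position. No measurement available here accounts for the step.

As far as these compounds go, whether a phenyl ring or an amine on this aromatic carbon would stay close to furan-3-yl or to thiophen-3-yl remains open. Also open, from the compounds shown here alone, is whether the same exchange gives a step of similar size when the methylsulfanyl group elsewhere on the core is replaced by a methoxy or a chloro group.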